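Cyclopropyl for ethyl at the assay's limit

This account rests on a few compounds, and the source may have more. Where it says the series, first, only, none or still open, it means among the compounds named here.

Of the compounds shown here, three have so far been read in an in vitro ADME assay on microsomes from liver (Homo sapiens) for metabolic stability; on this read-out higher numbers stand for fast clearance and lower numbers for slow clearance. Compound 1 `Cc1cnc(NC(=O)c2cc(Oc3cnc(C(=O)N(C)C)cn3)c3cc(C)oc3c2)cn1` gives < 8 mL/min/kg as a limit of the assay and not as a number. Compound 2 `CCS(=O)(=O)c1ccc(Oc2cc(C(=O)Nc3cnc(C)cn3)cc3nn(C)cc23)cc1` gives < 8 mL/min/kg as a limit too. Compound 3 `CCn1cc2c(Oc3ccc(S(C)(=O)=O)cc3)cc(C(=O)Nc3cnc(C)cn3)cc2n1` gives < 8 mL/min/kg as a limit as well. Compound 3 therefore has no exact number of its own, and it stands with the other two at a single mark (the limit of < 8 mL/min/kg in this assay, at which 3 of the 3 values shown sit).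

Compound 4 `Cc1cnc(NC(=O)c2cc(Oc3ccc(S(C)(=O)=O)cc3)c3cn(C4CC4)nc3c2)cn1` differs from compound 3 in one place, with cyclopropyl in place of ethyl on an aromatic nitrogen. Going by the values given here, no measured pair of compounds shows what this swap does, so there is no direct precedent to lean on. Starting from compound 3 at < 8 mL/min/kg as a limit, no step beyond the usual scatter is expected in this assay in either direction. The estimated step of a number no lower from compound 3 to compound 4 (the limit leaves the size open) is accordingly a small one. The assay may well report only a limit again for the new compound. Compound 4 is expected at 8 mL/min/kg with an estimated range of 5 mL/min/kg to 14 mL/min/kg in this assay as the read-out.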

Compound 4, clearance: < 8 mL/min/kg
Compound 4 gave a limit, no number; the forecaster's own chance of this, stated with the estimate: 65%; the middle value sits exactly at the limit.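

No step can be read from compound 3 to compound 4 in this assay, since each gives only a limit and not a number, so the effect of cyclopropyl in place of ethyl stays hidden: the limit of < 8 mL/min/kg in this assay, at which 4 of the 4 values shown sit.

The compounds shown leave open how fast any of them is actually cleared, and whether these two groups on the aromatic nitrogen differ at all in this assay.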